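The source may hold more compounds than are shown below. What is called first, only, known or untested is meant among the compounds shown, and "the series" means these compounds.

Measured in a functional assay on MOLT-3 cells (Homo sapiens); a higher number here means a weaker inhibitor, a lower number a stronger inhibitor:
Compound 1 `CC(C)=CCC/C(C)=C/CC/C(C)=C/CSC[C@H](NC(=O)OC(C)(C)C)C(=O)C=[N+]=[N-]`: 50100 nM
Compound 2 `CC(=O)N[C@@H](CSC/C=C(\C)CC/C=C(\C)CCC=C(C)C)C(=O)CCl`: 1400 nM

Of the two measured compounds, compound 2 gives the lower number in this assay, and its gap to compound 1 lies well beyond the scatter. Among the compounds with values here, the two differ in more than one place, so no single step between them can be read off; only their two values stand.

Compound 3 `CC(C)=CCC/C(C)=C/CC/C(C)=C/CSC[C@H](NC(=O)OC(C)(C)C)C(=O)CCl` is not yet measured. It differs from compound 2 by tert-butoxy in place of methyl on a carbonyl carbon. Within the data shown here, nothing measured here isolates that change, so there is no step to lean on. The expectation for compound 3 is a weakening, because compound 1, which also carries the tert-butoxycarbonyl group, gives 50100 nM, though compound 1 differs in a second place as well. The step expected from compound 2 to compound 3 is a 2.5-fold higher number from compound 2 to compound 3 (0.40 log units; beyond the scatter). Compound 3 is estimated at 3500 nM, within a range from 700 nM to 17000 nM.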

Compound 3, half-maximal inhibitory concentration: 7700 nM
The estimate for compound 3 lay 2.2-fold (0.34 log units) below the measured number; the measured number falls inside the stated range.
By their numbers in this assay, from the lowest: compound 2; then compound 3; then compound 1.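

Within the data shown here, compound 3 provides the first single-place comparisons in this assay, and each of the two changes can now be read alone. With the rest of the structure held constant, tert-butoxy in place of methyl on the carbonyl carbon whose other neighbour is the amide-type nitrogen weakens inhibition, with a 5.5-fold higher number from compound 2 to compound 3 (0.74 log units; beyond the scatter), while keeping the tert-butoxycarbonyl group and placing the chlorine-bearing group where the nitrogen-bearing group stood on a carbonyl carbon strengthens it, with a 6.5-fold lower number from compound 1 to compound 3 (0.81 log units; beyond the scatter). Both steps lie beyond the scatter, but nothing available explains either of them.

As far as these compounds go, it remains open whether the acetyl to tert-butoxycarbonyl step would keep its size with the nitrogen-bearing group in place. From the compounds shown here alone, how an amine or a longer chain on that same carbonyl carbon would read also remains open.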